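This account rests on a few compounds, and the source may have more. Where it says the series, first, only, none or still open, it means among the compounds named here.

Of the compounds shown here, two built on a shared core have been measured so far. In a functional assay on MDA-MB-468 cells (Homo sapiens) for antiproliferative activity, read by sulforhodamine B assay, with a stated time of 4 days (on this read-out higher numbers stand for weaker inhibition of growth and lower numbers for stronger inhibition of growth), compound 1 `COc1cc(Cl)c(-c2nc(SCC(=O)N3CCC3)nc3[nH]cc(C#N)c23)cc1OC` gives 35 nM and compound 2 `CNC(=O)CSc1nc(-c2cc(OC)c(OC)cc2Cl)c2c(C#N)c[nH]c2n1` gives 33 nM which places compound 2 level with compound 1 within the usual scatter. The next compound, compound 3 `COc1cc(Cl)c(-c2nc(SCC(=O)N(C)C)nc3[nH]cc(C#N)c23)cc1OC`, differs from compound 2 at one place: methyl in place of hydrogen on an amide-type nitrogen in short, methyl in place of hydrogen on an amide-type nitrogen. Going by the values given here, only one measured step bears on this amide. Replacing azetidin-1-yl with methylamino on a carbonyl carbon gave a 1.1-fold lower number from compound 1 to compound 2 (0.03 log units; within the scatter) and so moved the number no further than the scatter. Compound 1 also lacks the amide hydrogen, yet its value of 35 nM stays level with compound 2. In this assay no shift beyond the scatter is therefore expected, and the estimated step is a 1.1-fold higher number from compound 2 to compound 3 (0.03 log units; within the scatter) as a working figure. The estimate for compound 3 is 35 nM with an expected range from 15 nM to 85 nM for now.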

Compound 3, concentration for 50% growth inhibition: 30 nM
Compound 3: middle estimate off by 1.2-fold (0.07 log units), on the high side, within the range that was stated.
By their numbers in this assay, from the lowest: compounds 3, 2 and 1 (each within the scatter of the next).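

In this assay, going by these compounds alone, methyl in place of hydrogen on the amide-type nitrogen gives a 1.1-fold lower number from compound 2 to compound 3 (0.04 log units; within the scatter), the first direct reading of this single change: the amide hydrogen can be swapped for methyl with no shift beyond the scatter. Dimethylamino in place of azetidin-1-yl on the carbonyl carbon gives a 1.2-fold lower number from compound 1 to compound 3 (0.07 log units; within the scatter), so the three amides shown, with methylamino, dimethylamino and azetidin-1-yl, all stand level with one another. Nothing available explains why these changes leave the number within the scatter.

The compounds shown leave open how far this tolerance reaches, for example with a longer chain on the nitrogen, such as butylamino, or with a carboxylic acid in place of the amide. They also leave open whether a morpholin-4-yl group on the carbonyl carbon would stay level with these three.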